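The source may report more compounds than this note shows. Statements on the series, on what has been measured and on what is new or still open speak of the compounds shown alone.

Compound 1 `C[C@H](NC(=O)c1c(-c2ccccc2)nnn1Cc1ccccc1)c1ccc(C(=O)O)cc1` gives 647 nM in a functional assay on CHO cells for antagonist activity at prostaglandin E2 receptor EP4 subtype (Homo sapiens), read by calcium flux, with a stated time of 15 min; a higher number here means a weaker inhibitor, a lower number a stronger inhibitor.
Compound 2 `C[C@H](NC(=O)c1c(-c2ccccc2)nnn1Cc1ccc(F)cc1)c1ccc(C(=O)O)cc1` gives 330 nM in this assay.
Compound 3 `COc1cccc(Cn2nnc(-c3ccccc3)c2C(=O)N[C@@H](C)c2ccc(C(=O)O)cc2)c1` gives 96.8 nM in this assay.

Compound 3 stands lowest of the three numbers in this assay, with compound 2 nearest and compound 1 furthest, both gaps beyond the scatter. Compound 4 `COc1ccc(Cn2nnc(-c3ccccc3)c2C(=O)N[C@@H](C)c2ccc(C(=O)O)cc2)cc1F` differs from compound 3 by 3-fluoro-4-methoxyphenyl in place of 3-methoxyphenyl on a saturated chain carbon bound to an aromatic nitrogen. For the measured compounds named here, two measured steps bear on this change: a 2.0-fold lower number from compound 1 to compound 2 (0.29 log units; within the scatter) and a 6.7-fold lower number from compound 1 to compound 3 (0.83 log units; beyond the scatter). Going by the values given here, the fluoro step lay within the scatter, the methoxy step beyond it, and no measured pair shows the methoxy where it sits in compound 4. The step of a 1.3-fold higher number from compound 3 to compound 4 (0.13 log units; within the scatter) is therefore expected to stay within the scatter. Compound 4 is estimated at 130 nM, with a range of 40 nM to 450 nM.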

Compound 4, half-maximal inhibitory concentration: 29.8 nM
Estimate against measurement, compound 4: 4.4-fold (0.64 log units) above; measured number below the stated range.
By their numbers in this assay, from the lowest: compound 4; then compound 3; then compounds 2 and 1 (each within the scatter of the next).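

The 3-fluoro-4-methoxyphenyl group gives a 3.2-fold lower number from compound 3 to compound 4 (0.51 log units; beyond the scatter) in this assay and so improves on the 3-methoxyphenyl group, the best of the earlier groups at this position. Against the other two groups it gives an 11-fold lower number from compound 2 to compound 4 (1.04 log units; beyond the scatter) and a 22-fold lower number from compound 1 to compound 4 (1.34 log units; beyond the scatter) as the first large steps here. No measurement given here accounts for this gain.

The change adds a fluoro group and also places the methoxy differently, and the compounds shown do not separate the two. On these data alone, how 4-methoxyphenyl alone, or a chloro or ethoxy group on this ring, would read remains open.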